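The compounds below may be only part of what the source reports. "The series", "measured", "known", "first", "only" and "open" are said of these compounds alone.

Measured in an ADME assay on microsomes from liver (Mus musculus) for metabolic stability, read by LC-MS, with a stated time of 1 h, tested at 5 uM; a higher number here means that more of the compound is left, a lower number that less of the compound is left:
Compound 1 `Cc1ccc(C)c(N2CCN(C(=O)c3oc(C)nc3-c3ccccc3)CC2)c1`: 1.4%
Compound 2 `COc1cc(OC)cc(N2CCN(C(=O)c3oc(C)nc3-c3ccc(F)cc3)CC2)c1`: 5.6%
Compound 3 `CCC[C@H](Nc1nc(-c2ccc(NC(=O)NCC)c(OC)c2)ncc1C)c1cccnc1`: 87.5%

Very little of compound 1 survives, with 1.4% left. That value lies within the usual scatter of compound 2, at 5.6%. Compound 3 gives 87.5%, and its wide gap to compound 1 lies beyond the scatter.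

Compound 4 `Cc1nc(-c2ccccc2)c(C(=O)N2CCN(c3cc(Cl)cc(Cl)c3)CC2)o1` carries 3,5-dichlorophenyl in place of 2,5-dimethylphenyl on an amine nitrogen in a ring. For the measured compounds named here, no measured pair shows this kind of swap directly. Compound 2 shares the core of compound 1, and compound 2 still gives only 5.6%, so little survival is expected here too.

The expected change is a number 6.6 percentage points higher from compound 1 to compound 4 (within the scatter), an estimated small rise that may stay within the scatter. For compound 4 the estimate is 8%, with an expected range from 1% to 28%.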

Compound 4, percent of the compound remaining: 43.4%
Beside the measured number, compound 4's estimate is 35.4 percentage points below it; measured number above the stated range.
By their numbers in this assay, from the lowest: compounds 1 and 2 (each within the scatter of the next); then compound 4; then compound 3.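

In this assay, 3,5-dichlorophenyl in place of 2,5-dimethylphenyl on the amine nitrogen in the ring gives a number 42 percentage points higher from compound 1 to compound 4 (beyond the scatter). The earlier compounds shown here did not show that this position can matter so much, and here it does with an equal heavy-atom count in the group that leaves and the group that enters. No measurement shown here accounts for the rise.

This single step alters both the kind of substituent and where it sits, so the two cannot be separated. Going by these compounds, whether 3,5-dimethylphenyl, or a phenyl ring carrying a nitrile or trifluoromethyl, would behave the same stays open.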